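The source may report more compounds than this note shows. Statements on the series, on what has been measured and on what is new or still open speak of the compounds shown alone.

Of the compounds shown here, three built on one shared core have been measured in an assay on CHO cells for antagonist activity at transient receptor potential cation channel subfamily V member 1 (Homo sapiens), read by FLIPR; a higher number here means a weaker inhibitor, a lower number a stronger inhibitor. Compound 1 `CCC1CCN(c2cc(C(F)(F)F)ccc2CNC(=O)C(C)c2ccc(NS(C)(=O)=O)c(F)c2)CC1` gives 0.7 nM, compound 2 `CCCCCCSc1cc(C(F)(F)F)ccc1CNC(=O)C(C)c1ccc(NS(C)(=O)=O)c(F)c1` gives 1.8 nM, and compound 3 `CC(C(=O)NCc1ccc(C(F)(F)F)cc1SC1CCCC1)c1ccc(NS(C)(=O)=O)c(F)c1` gives 0.3 nM. Compound 3 holds the lowest of the three numbers: the step of a 2.3-fold lower number from compound 1 to compound 3 (0.37 log units; beyond the scatter), and the step of a 6.0-fold lower number from compound 2 to compound 3 (0.78 log units; beyond the scatter). Between the other two, the step of a 2.6-fold higher number from compound 1 to compound 2 (0.41 log units; beyond the scatter). All three steps alter the group on the same aromatic carbon of the core, and each of them remains modest.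

Compound 4 `CC(C(=O)NCc1ccc(C(F)(F)F)cc1[N+](=O)[O-])c1ccc(NS(C)(=O)=O)c(F)c1` has not yet been measured. Its change from compound 3 is nitro in place of cyclopentylsulfanyl on an aromatic carbon. The three measured steps bear on this change in that they also vary the group on that aromatic carbon, but none of them introduces a nitro group, so they fix the size of what can be expected rather than its direction. Since compound 3 sits lowest and the steps at this position have been modest, the step from compound 3 to compound 4 is expected to be a higher number in this assay, of modest size, as a 10-fold higher number from compound 3 to compound 4 (1.00 log units; beyond the scatter). Compound 4 is therefore estimated to give 3 nM, within a range from 0.8 nM to 12 nM.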

Compound 4, inhibition constant: "not active" (no number reported)
The entry for compound 4 holds no number; the estimate stays without a comparison.
By their numbers in this assay, from the lowest: compound 3; then compound 1; then compound 2.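

In this assay, among these compounds, compound 4 is recorded as "not active" with no number, so no step from compound 3 to compound 4 can be read. The compounds shown leave open how far the nitro group in compound 4 sets it apart from compound 3 in inhibition constant. No measurement shown accounts for this result.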